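Sulfonyl aryl swap on the piperidine amide series

The compounds below may be only part of what the source reports. "The series", "measured", "known", "first", "only" and "open" are said of these compounds alone.

The shared core of this series carries an amide and a ring-bound sulfonamide nitrogen; the sulfonyl aryl is the variable part. Compound 1 `CCN(Cc1ccccc1)C(=O)C1CCN(S(=O)(=O)c2ccccc2)CC1` is the phenyl sulfonyl parent, and in a functional assay on CHO cells for positive allosteric modulation of muscarinic acetylcholine receptor M5 (Homo sapiens), read by calcium flux (on this read-out higher numbers stand for larger maximal responses and lower numbers for smaller maximal responses), compound 1 gives 69%. Compound 2 `CCN(Cc1ccccc1)C(=O)C1CCN(S(=O)(=O)c2ccc(C(F)(F)F)nc2)CC1` bears a trifluoromethyl-substituted pyridyl sulfonyl; in this assay compound 2 gives "not determined" (no result reported), so no number stands for it. Compound 3 `CCN(Cc1ccccc1)C(=O)C1CCN(S(=O)(=O)c2ccncc2)CC1` is the plain pyridin-4-yl sulfonyl; in this assay compound 3 gives "not determined" (no result reported), so it also stands without a number. Compound 3 therefore cannot be placed against compound 1 on the numbers shown, and no step between measured compounds is available within the series.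

Compound 4 `CCN(Cc1ccccc1)C(=O)C1CCN(S(=O)(=O)c2ccc3cccnc3c2)CC1` is the next member. The change from compound 3 to compound 4 is quinolin-7-yl in place of pyridin-4-yl on a sulfonyl sulfur. Going by the values given here, no measured step supports a direction for this change, so the only anchor for an expectation is compound 1 at 69% in this assay, and the maximal response of compound 4 is expected to sit within the scatter of that anchor rather than to move clearly up or down. The estimate for compound 4 in this assay is 70%, with a range from 40% to 100%.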

Compound 4, largest response reached (reported as percent of maximum), in percent of the reference or control that the assay uses: 66%
Compound 4: middle estimate off by 4 percentage points, on the high side; low and high end bracket the measured number.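

Going by these compounds alone, this result gives the first step at the sulfonyl aryl position that can be read: in this assay, quinolin-7-yl in place of phenyl on a sulfonyl sulfur gives a number 3 percentage points lower from compound 1 to compound 4 (within the scatter). The position therefore accepts a second six-membered aromatic ring, with a ring nitrogen, and the maximal response stays within the scatter of the phenyl parent, although this rests on a single pair and steps involving compound 2 or compound 3 cannot be read. No measured data bearing on this outcome are available, so the result stands as an observation only.

With no number for the pyridin-4-yl or trifluoromethyl-substituted pyridyl sulfonyl compounds, the compounds shown leave open whether a single aromatic ring containing nitrogen behaves like phenyl or quinolin-7-yl at this position. They also leave open how the maximal response changes when the sulfonyl sulfur carries an aryl bearing an amine or a carboxylic acid, or a saturated ring such as cyclohexyl in place of an aromatic one.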